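A few compounds are considered here, and "the series" means these few. Any claim that something is new, unique, unknown or untested is made for them only; others in the source may bear on it.

Measured so far in a functional assay on BGC-823 cells (Homo sapiens) for cytotoxicity, read by MTT assay; a higher number here means a weaker inhibitor, a lower number a stronger inhibitor:
Compound 1 `Cc1cccc(Nc2nc(C)c(C(=O)/C=C/c3ccccc3Cl)s2)c1` gives 24200 nM.
Compound 2 `Cc1ccc(Nc2nc(C)c(C(=O)/C=C/c3ccc(Cl)cc3)s2)cc1` gives > 25000 nM, which is a limit of the assay and not a number.
Compound 3 `COc1cc(/C=C/C(=O)c2sc(Nc3cccc(Cl)c3)nc2C)cc(OC)c1OC` gives 11600 nM.

Of the two numbers, compound 3 holds the lower one; the nearer of the others belongs to compound 1, which sits at a higher number, with a gap beyond the usual scatter. From the compounds shown here alone, compound 2 sits at the limit of > 25000 nM in this assay, at which 1 of the 3 values shown sits, so its place among the others stays open.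

Compound 4 `COc1cc(/C=C/C(=O)c2sc(Nc3ccccc3)nc2C)cc(OC)c1OC` has not yet been measured. It differs from compound 3 in one place: hydrogen in place of chloro on an aromatic carbon, the same difference cut one bond further out reading 3-chlorophenyl to phenyl. For the measured compounds named here, no pair of measured compounds shows this change on its own, so there is no measured step to lean on. The expectation is a small step in this assay, toward a somewhat higher number, of about a 1.4-fold higher number from compound 3 to compound 4 (0.14 log units; within the scatter), within or at the edge of the scatter. Compound 4 is therefore estimated at 16000 nM, with a likely range from 6000 nM to 40000 nM.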

Compound 4, half-maximal inhibitory concentration: > 25000 nM
Compound 4: no number, only a limit; the forecaster's own chance of this, stated with the estimate: 25%; middle value at least 1.5-fold (0.19 log units) from the limit.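

For the compounds shown here, this pair is the first to isolate a single change, and it shows that the chloro of the 3-chlorophenyl group matters in this assay: replacing it with hydrogen gives an at least 2.1-fold higher number from compound 3 to compound 4 (0.33 log units; beyond the scatter), a step beyond the scatter and larger than expected. Compound 4 gives > 25000 nM, which is a limit of the assay and not a number. The step therefore sets only a minimum, and its full size cannot be read, as compound 4 joins another compound at the top of the reported range: the limit of > 25000 nM in this assay, at which 2 of the 4 values shown sit.

From the compounds shown here alone, whether fluoro, bromo or an amine at this same place would match chloro, or give a lower number, remains open. So does whether removing the chloro would have the same effect on compounds with a different group on the other aromatic ring.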